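The compounds below may be only part of what the source reports. "The series", "measured", "known", "first", "only" and "open" are said of these compounds alone.

Measured compounds:
- compound 1, `CC1=CC[C@H](C(C)C)c2cc(C)c(OC(=O)c3ccc(Cl)cc3)cc21`: 58.9%
- compound 2, `CC1=CC[C@H](C(C)C)c2cc(C)c(OC(=O)c3cccc(C(F)(F)F)c3)cc21`: 45.5%

In a functional assay on K562 cells (Homo sapiens) for antiproliferative activity, read by sulforhodamine B assay, with a stated time of 48 h, tested at 50 uM (on this read-out lower numbers stand for less inhibition and higher numbers for more inhibition at the one concentration tested (going by the name of the read-out)), compound 1 gives 58.9%. Compound 2 is the other measured ester; in this assay compound 2 gives 45.5%, the lower of the two numbers, and the gap to compound 1 lies beyond the usual scatter. The two compounds share the same core and the same ester linkage and differ only in the substituent pattern of the benzoate ring, so nothing more can be said of them than what their two values show.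

Compound 3, `CC1=CC[C@H](C(C)C)c2cc(C)c(OC(=O)c3cccc(C)c3)cc21`, is not yet measured in this assay. Its structure differs from compound 2 in one place: methyl in place of trifluoromethyl on an aromatic carbon. For the measured compounds named here, since no single-change step between measured compounds is available, the size of this step can only be guessed. The account expects the step from compound 2 to compound 3 to be a number 2.5 percentage points higher from compound 2 to compound 3 (within the scatter), a change that is not expected to reach beyond the scatter in either direction. Compound 3 is therefore estimated to give 48% in this assay, with a range from 30% to 66%.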

Compound 3, a percentage reported as inhibition, at one concentration (the size of the read-out at that concentration, not a potency): "not active" (no number reported)
Compound 3: no number reported; no gap can be computed for the estimate.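

In this assay, for the compounds shown here, compound 3 is reported as "not active" (no number reported) and carries no number, and no step from compound 2 to compound 3 can be read. Nothing shown bears on the cause of this result. The compounds shown leave open how the change from trifluoromethyl to methyl alters the inhibition in numbers.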